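The source may hold more compounds than are shown below. What is called first, only, known or untested is meant among the compounds shown, and "the series" means these compounds.

Compound 1 `O=c1cc(C2CCC2)oc2ccc(OCCCCCCN3CCCCC3)cc12` gives 34 nM in an assay on isolated protein (Cavia porcellus) with Sigma non-opioid intracellular receptor 1 (Homo sapiens) as the target, read by radioligand binding; on this read-out higher numbers stand for weaker inhibition and lower numbers for stronger inhibition.
Compound 2 `O=c1cc(C2CCCC2)oc2ccc(OCCCCCCN3CCCCC3)cc12` gives 38 nM in this assay.
Compound 3 `O=c1cc(C2CCCCC2)oc2ccc(OCCCCCCN3CCCCC3)cc12` gives 32 nM in this assay.

The three measured compounds share one core and differ only in the ring that hangs from it. Compound 3 shows the lowest of the three numbers, but none of the three can be called more or less potent than another, since every step between them stays within the scatter: a 1.1-fold higher number from compound 1 to compound 2 (0.05 log units; within the scatter), a 1.1-fold lower number from compound 1 to compound 3 (0.03 log units; within the scatter) and a 1.2-fold lower number from compound 2 to compound 3 (0.07 log units; within the scatter).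

Compound 4 `O=c1cc(-c2cccnc2)oc2ccc(OCCCCCCN3CCCCC3)cc12` is the next step from compound 3, and the change is pyridin-3-yl in place of cyclohexyl on an aromatic carbon. The measured steps all exchange one non-aromatic ring of carbon only for another of a different size, and in each case the read-out barely moved. Among the measured compounds shown here, none of them exchanges such a ring for an aromatic ring with a hetero atom, so there is no direct measured precedent for this change. What the measured steps do show is that the read-out has so far tolerated several different rings in this place without a change beyond the scatter. On that basis the step is expected to be small, a 1.4-fold higher number from compound 3 to compound 4 (0.15 log units; within the scatter), with a wider range to allow for the new kind of ring. Compound 4 is therefore estimated at 45 nM, between 15 nM and 140 nM.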

Compound 4, half-maximal inhibitory concentration: 192 nM
Beside the measured number, compound 4's estimate is 4.3-fold (0.63 log units) below it; the whole stated range lies below it.
By their numbers in this assay, from the lowest: compounds 3, 1 and 2 (each within the scatter of the next); then compound 4.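

The carbon next to the ring oxygen proves less forgiving than the three carbon rings suggested: changing the size of that non-aromatic ring left this assay within the scatter, yet replacing cyclohexyl with pyridin-3-yl, which has the same number of heavy atoms, gives a 6.0-fold higher number from compound 3 to compound 4 (0.78 log units; beyond the scatter) and so weaker inhibition. Weaker inhibition follows whichever carbon ring is the starting point, with a 5.1-fold higher number from compound 2 to compound 4 (0.70 log units; beyond the scatter) and a 5.6-fold higher number from compound 1 to compound 4 (0.75 log units; beyond the scatter) as the other two steps. This single change makes the ring aromatic and also brings in a ring nitrogen counted as a hydrogen-bond acceptor, and nothing available here explains the rise in the number.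

A phenyl ring in this place would separate the effect of an aromatic ring from that of the nitrogen, a comparison the compounds shown do not offer. Also open, going by these compounds, is whether pyridin-2-yl or pyridin-4-yl, with the nitrogen elsewhere in the ring, or piperidinyl, a non-aromatic ring holding a nitrogen, would read like compound 4 or like the carbon rings.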